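Changing an Amide to a Urea on a Shared Core

The source may report more compounds than this note shows. Statements on the series, on what has been measured and on what is new or still open speak of the compounds shown alone.

Three compounds share one core and were tested in a functional assay on SK-BR-3 cells (Homo sapiens) for inhibition, read by MTT assay, with a stated time of 2 days, tested at 10 uM; a lower number here means less inhibition of growth, a higher number more inhibition of growth at the concentration tested. Compound 1 `CNC(=O)c1cc(Oc2ccc3nc(NC(=O)Nc4ccc(C5CCN(C(C)C)CC5)cc4)sc3c2)ccn1` gives 45%. Compound 2 `CNC(=O)c1cc(Oc2ccc3nc(NC(=O)c4cc(Cl)cc(Cl)c4)sc3c2)ccn1` gives 9.62%, and compound 3 `CNC(=O)c1cc(Oc2ccc3nc(NC(=O)c4cccc(F)n4)sc3c2)ccn1` gives 12.5%, the second highest of the three. Within the data shown here, the one single-point step measured so far, a number 2.9 percentage points higher from compound 2 to compound 3 (within the scatter), did not change the number beyond the scatter. Compound 4 `CNC(=O)c1cc(Oc2ccc3nc(NC(=O)Nc4ccc(Br)cc4)sc3c2)ccn1` differs from compound 3 by (4-bromophenyl)amino in place of 6-fluoropyridin-2-yl on a carbonyl carbon. Among the measured compounds shown here, no measured step matches this change; compound 1, the only other compound carrying an arylamino group on the carbonyl carbon, does show a higher number than compound 3. Compound 4 is therefore expected to rise by a number 17.5 percentage points higher from compound 3 to compound 4 (beyond the scatter) in this assay. The estimate for compound 4 is 30%, with a range from 10% to 55%.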

Compound 4, percent growth inhibition at one concentration: 26.7%
Estimate against measurement, compound 4: 3.3 percentage points above, and the stated range covers the measured number.
By their numbers in this assay, from the lowest: compounds 2 and 3 (each within the scatter of the next); then compound 4; then compound 1.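

In this assay, (4-bromophenyl)amino on the carbonyl carbon brings a number 14.2 percentage points higher from compound 3 to compound 4 (beyond the scatter) and a number 17.1 percentage points higher from compound 2 to compound 4 (beyond the scatter) without any 1-isopropylpiperidin-4-yl group, so that group is not required for a rise beyond the scatter at this position. Still, bromo in its place on the aromatic carbon brings a number 18.3 percentage points lower from compound 1 to compound 4 (beyond the scatter) and so the choice of group there also matters for these compounds. Nothing measured here explains these steps. Also open, from the compounds shown here alone, is how a morpholine or a carboxylic acid on that aromatic carbon would compare with bromo.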